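The source may report more compounds than this note shows. Statements on the series, on what has been measured and on what is new or still open speak of the compounds shown alone.

Going by the values given here, compound 1, `CC1=CC[C@H](C(C)C)c2cc(C)c(OC(=O)Nc3ccccc3)cc21`, stands at the top of the two numbers measured so far in a functional assay on HCT-15 cells (Homo sapiens) for antiproliferative activity, read by sulforhodamine B assay, with a stated time of 48 h, tested at 50 uM; on this read-out lower numbers stand for less inhibition and higher numbers for more inhibition at the one concentration tested (going by the name of the read-out). In this assay compound 1 gives 92%. Among the compounds with values here, the only other measured compound, compound 2, `Cc1cc2c(C(C)C)ccc(C)c2cc1OC(=O)c1ccc(C(F)(F)F)cc1`, gives 55.6% in this assay, a number well below that of compound 1 and beyond the usual scatter; since the two differ in more than one place, no single structural step can be read from that gap. Compound 3, `CC1=CC[C@H](C(C)C)c2cc(C)c(OC(=O)c3ccc(Cl)cc3)cc21`, is the compound still to be measured in this assay. It arises from compound 1 through one change: 4-chlorophenyl in place of anilino on a carbonyl carbon. Within the data shown here, no measured pair shows this exact change, so its effect has to be judged from compound 2, the only measured compound without an anilino group on the carbonyl carbon, which gives 55.6%. For compound 3 the expected step is a number 20 percentage points lower from compound 1 to compound 3 (beyond the scatter), a decrease that is expected to lie beyond the scatter while staying clear of the level of compound 2. The estimate for compound 3 in this assay is 72%, within an expected range from 48% to 90%.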

Compound 3, a percentage reported as inhibition, at one concentration (the size of the read-out at that concentration, not a potency): 47.4%
For compound 3 the middle estimate is 24.6 percentage points above the measured one; the measured number lies below the stated range.
By their numbers in this assay, from the lowest: compounds 3 and 2 (each within the scatter of the next); then compound 1.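

In this assay, going by these compounds alone, the carbonyl carbon proves sensitive to what it carries: 4-chlorophenyl in place of anilino gives a number 44.6 percentage points lower from compound 1 to compound 3 (beyond the scatter) and is the first direct reading of a change at this place, since the earlier compounds differed in more than one place. The step is large even though the two groups have the same number of heavy atoms and each has one six-membered aromatic ring of carbon only; they differ in that anilino brings a nitrogen and a hydrogen-bond donor, while 4-chlorophenyl brings a chlorine and no donor. No measurement at hand says which of these differences accounts for the step.

The compounds shown leave open whether the step belongs to the loss of the nitrogen of anilino or to the arrival of the chlorine, which a plain phenyl or a 4-chloroanilino group on the same carbonyl carbon would separate. They also leave open whether the aromatic ring of anilino matters at all, as a cyclohexylamino group at this place would show.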